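Chloro for fluoro on the aryl ether of a bile acid receptor agonist

The compounds below may be only part of what the source reports. "The series", "measured", "known", "first", "only" and "open" are said of these compounds alone.

This account concerns compound 2 `CC(C)c1onc(-c2c(Cl)cccc2Cl)c1COc1ccc(-c2nc3ccc(C(=O)O)cc3n2CC2CCCCC2)c(F)c1` and its chloro analogue compound 3 `CC(C)c1onc(-c2c(Cl)cccc2Cl)c1COc1ccc(-c2nc3ccc(C(=O)O)cc3n2CC2CCCCC2)c(Cl)c1`. In an assay on isolated protein for agonist activity at Bile acid receptor (Homo sapiens), read by TR-FRET (a higher number here means that more compound is needed for the effect, a lower number that less compound is needed), compound 2 is recorded as "not determined" (no result reported); it has no single number. The related compound 1 `CCC(CC)n1c(-c2ccc(OCc3c(-c4c(Cl)cccc4Cl)noc3C(C)C)cc2F)nc2ccc(C(=O)O)cc21` does have a value, and in this assay compound 1 gives 69.3 nM. Compound 3 differs from compound 2 by chloro in place of fluoro on an aromatic carbon. For the measured compounds named here, no step between measured compounds is available, so no direction can be drawn from data; the step from compound 2 to compound 3 in this assay is expected to stay within the usual scatter. Compound 3 is therefore estimated at 70 nM, with a range from 15 nM to 350 nM.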

Compound 3, half-maximal effective concentration: 66.1 nM
Estimate against measurement, compound 3: 1.1-fold (0.02 log units) above; the range from low to high includes it.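

In this assay, for the compounds shown here, compound 2 has no single number, so no step from it to compound 3 can be read. What chloro in place of fluoro does to the read-out stays open, and no evidence shown bears on it.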